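The compounds below may be only part of what the source reports. "The series", "measured", "known", "first", "only" and "open" are said of these compounds alone.

Compound 3 `O=C1[C@@H]2C(c3ccccc3)OC3(C(=O)c4ccccc4C3=O)[C@@H]2C(=O)N1c1ccc(Cl)c(C(F)(F)F)c1` was examined in an assay on isolated protein for inhibition of phenylalanine--tRNA ligase, mitochondrial (Homo sapiens); a lower number here means a stronger inhibitor, a higher number a weaker inhibitor. In this assay compound 3 gives only a limit, > 100000 nM. Compound 1 `O=C1[C@@H]2C(c3ccccc3)OC3(C(=O)c4ccccc4C3=O)[C@@H]2C(=O)N1c1ccc(Cl)c(Cl)c1` also gives only a limit in this assay, > 100000 nM. Compound 2 `O=C1[C@@H]2C(c3ccccc3)NC3(Cc4ccccc4C3)[C@@H]2C(=O)N1c1ccc(Cl)c(Cl)c1` likewise gives only a limit in this assay, > 100000 nM. Going by the values given here, the single one-place step, a step that the two limits leave unreadable from compound 1 to compound 3, cannot be sized because of the limit of > 100000 nM in this assay, at which 3 of the 3 values shown sit. Compound 4 `COc1ccc(N2C(=O)[C@@H]3C(c4ccccc4)OC4(C(=O)c5ccccc5C4=O)[C@@H]3C2=O)cc1` differs from compound 3 by 4-methoxyphenyl in place of 4-chloro-3-(trifluoromethyl)phenyl on an amide-type nitrogen in a ring. Among the compounds with values here, no measured step bears directly on this change, and every measured value sits at the same limit. Compound 4 is therefore expected to stay near that limit, so that a step that the limit leaves unreadable from compound 3 to compound 4 is the expected step. For compound 4 the estimate is 150000 nM, with a range from 50000 nM to 500000 nM.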

Compound 4, half-maximal inhibitory concentration: > 100000 nM
Compound 4: only a limit was reported; the forecaster's own chance of this, stated with the estimate: 85%; the middle value lies beyond the limit too.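

Going by these compounds alone, compound 4, like compound 3 and compound 1, gives only a limit, so no step between them can be read: the limit of > 100000 nM in this assay, at which 4 of the 4 values shown sit. The compounds shown leave open which group on the amide-type nitrogen, if any, would give a measurable inhibition value.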